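A few compounds are considered here, and "the series" means these few. Any claim that something is new, unique, unknown or untested is made for them only; others in the source may bear on it.

Of the compounds shown here, two carry measured numbers so far. In a functional assay on the whole organism for antagonist activity, with Rattus norvegicus as the target (a lower number here means that less compound is needed, a higher number that more compound is needed for the effect), compound 1 `COc1cc2c(cc1OC)C(CCN1CCN(c3cccc4c3OCCO4)CC1)CC2` gives 0.86 mg/kg, and compound 2 `C1=C(CCN2CCN(c3cccc4c3OCCO4)CC2)Cc2ccccc21` gives 0.36 mg/kg. Compound 2 stands lowest of the two numbers; compound 1 is the nearest, with a higher number that lies beyond the scatter. Compound 3 `c1ccc2c(c1)CCC2CCN1CCN(c2cccc3c2OCCO3)CC1` is not yet measured; it differs from compound 2 in one place: a group of 9 heavy atoms (9 carbon; one five-membered non-aromatic ring of carbon only, one six-membered aromatic ring of carbon only) in place of a group of 9 heavy atoms (9 carbon; one five-membered non-aromatic ring of carbon only, one six-membered aromatic ring of carbon only), on a saturated chain carbon, two bonds along the chain from an amine nitrogen in a ring. Among the compounds with values here, no measured step of this kind is in hand, so a change in this assay within the scatter is expected, with the direction open. The expected step is a 1.3-fold higher number from compound 2 to compound 3 (0.10 log units; within the scatter). Compound 3 is estimated at 0.45 mg/kg in this assay, with a range from 0.2 mg/kg to 1.1 mg/kg.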

Compound 3, dose for 50% inhibition: 1.29 mg/kg
Compound 3: the middle estimate sits 2.9-fold (0.46 log units) below what was measured; measured number outside the range, above it.
By their numbers in this assay, from the lowest: compound 2; then compounds 1 and 3 (each within the scatter of the next).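

In this assay the exchange for 2,3-dihydro-1H-inden-1-yl, which removes the double bond outside aromatic rings, brings a 3.6-fold higher number from compound 2 to compound 3 (0.55 log units; beyond the scatter) on a saturated chain carbon, two bonds along the chain from an amine nitrogen in a ring. Within the data shown here, this is the first readable step at this position, and it shows that the number responds to the change even though the heavy-atom count and ring types stay the same. No available evidence accounts for the step.

Still open, as far as these compounds go, is whether a longer chain at this position would keep the lower number of compound 2. Also open, from the compounds shown here alone, is how an amine or a carboxylic acid on the 2,3-dihydro-1H-inden-1-yl group would shift the number of compound 3.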